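The source may hold more compounds than are shown below. What is called first, only, known or untested is meant among the compounds shown, and "the series" means these compounds.

In a functional assay on IMR-32 cells (Homo sapiens) for antiproliferative activity, read by sulforhodamine B assay, with a stated time of 48 h (a lower number here means a stronger inhibitor, a higher number a weaker inhibitor), three compounds that share one core have been measured. Compound 1 (`COc1ccc(C[C@@H](O)/C=C/C=C/C(=O)N2CCCCC2)cc1OC`) gives 11000 nM, compound 2 (`COc1ccc(C[C@@H](O)/C=C/C=C/C(=O)NCc2ccc(Cl)cc2)cc1OC`) gives 15700 nM, and compound 3 (`CCN1CCN(C(=O)/C=C/C=C/[C@H](O)Cc2ccc(OC)c(OC)c2)CC1`) gives 10800 nM. Compound 3 therefore stands within the scatter of the other two, and no order can be read among the three. Compound 4 (`COc1ccc(C[C@@H](O)/C=C/C=C/C(=O)N2CCCC2)cc1OC`) has pyrrolidin-1-yl in place of 4-ethylpiperazin-1-yl on a carbonyl carbon. Among the compounds with values here, three measured steps bear on this change, as each swaps the group at that same place: a 1.4-fold higher number from compound 1 to compound 2 (0.15 log units; within the scatter), a 1.0-fold lower number from compound 1 to compound 3 (0.01 log units; within the scatter) and a 1.5-fold lower number from compound 2 to compound 3 (0.16 log units; within the scatter). All three are small and lie within the scatter, even though the groups exchanged in them are quite different. On that evidence, no step beyond the scatter is expected in this assay. The expected step is a 1.1-fold higher number from compound 3 to compound 4 (0.03 log units; within the scatter). For compound 4, the estimated value is 11500 nM, with an expected range from 6500 nM to 20000 nM.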

Compound 4, half-maximal inhibitory concentration: 12000 nM
Compound 4: middle estimate off by 1.0-fold (0.02 log units), on the low side; measured number inside the range.
By their numbers in this assay, from the lowest: compounds 3, 1, 4 and 2 (each within the scatter of the next).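

In this assay, a fourth group on the carbonyl carbon leaves the picture flat: pyrrolidin-1-yl gives no separation from 4-ethylpiperazin-1-yl (a 1.1-fold higher number from compound 3 to compound 4 (0.05 log units; within the scatter)), from (4-chlorobenzyl)amino (a 1.3-fold lower number from compound 2 to compound 4 (0.12 log units; within the scatter)) or from piperidin-1-yl (a 1.1-fold higher number from compound 1 to compound 4 (0.04 log units; within the scatter)), and each of these steps lies within the scatter. A five-membered ring with one hetero atom thus reads the same here as a six-membered ring with two, so neither ring size nor the second ring hetero atom separates these compounds. No measurement at hand accounts for this lack of response.

The compounds shown leave open whether a carboxylic acid, a primary amide or an open-chain amine at this place would separate from the four groups seen so far. They also leave open whether replacing the hydroxyl on the shared core would do so.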